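Naphthalen-1-yl in Place of Pyridin-4-yl: An Expectation

The source may report more compounds than this note shows. Statements on the series, on what has been measured and on what is new or still open speak of the compounds shown alone.

The measured compounds, all sharing one core and tested in an assay on CHO cells for displacement of a labelled ligand from adenosine receptor A3 (Homo sapiens), read by scintillation counting, with a stated time of 120 min, tested at 10 uM; a higher number here means more inhibition at the concentration tested (going by the name of the read-out), a lower number less inhibition:
- compound 1, `Nc1scc(CN2CCN(c3ccc([N+](=O)[O-])cc3)CC2)c1C(=O)c1ccc(Cl)cc1`, gives 2%
- compound 2, `Nc1scc(CN2CCN(c3cccnc3)CC2)c1C(=O)c1ccc(Cl)cc1`, gives 0%
- compound 3, `Nc1scc(CN2CCN(c3ccncc3)CC2)c1C(=O)c1ccc(Cl)cc1`, gives 2%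

Compound 3 stands level with compound 1 at the digits shown, and the two together are the highest of the three numbers, though the separation is small: a number 2 percentage points higher from compound 2 to compound 3 (within the scatter), which is within the scatter. In short, none of the three shows inhibition beyond the scatter of this kind of measurement.

Compound 4, `Nc1scc(CN2CCN(c3cccc4ccccc34)CC2)c1C(=O)c1ccc(Cl)cc1`, has not yet been tested. It differs from compound 3 in one place: naphthalen-1-yl in place of pyridin-4-yl on an amine nitrogen in a ring. The measured steps that bear on this change all swap one group on the same amine nitrogen in a ring: a number 2 percentage points lower from compound 1 to compound 2 (within the scatter), no change at the digits printed from compound 1 to compound 3 (within the scatter) and a number 2 percentage points higher from compound 2 to compound 3 (within the scatter). Each of these is within the scatter, so three different groups at this position all leave the read-out near zero. Within the data shown here, no measured step involves a group like naphthalen-1-yl, so its effect is untested.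

Compound 4 is therefore expected to give about 4%, within -6% to 22%, a step of a number 2 percentage points higher from compound 3 to compound 4 (within the scatter) that is not expected to exceed the scatter.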

Compound 4, a percentage reported as inhibition, at one concentration (the size of the read-out at that concentration, not a potency): 0%
Compound 4: the middle estimate sits 4 percentage points above what was measured; measured number inside the range.
By their numbers in this assay, from the lowest: compounds 2, 4, 1 and 3 (each within the scatter of the next).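

In this assay naphthalen-1-yl on the amine nitrogen in the ring gives a number 2 percentage points lower from compound 3 to compound 4 (within the scatter) and no change at the digits printed from compound 2 to compound 4 (within the scatter) as well as a number 2 percentage points lower from compound 1 to compound 4 (within the scatter) in the three comparisons. Among these compounds, the earlier compounds carried only a single aromatic ring at this position, so the new result extends the picture to a larger group, with two six-membered aromatic rings of carbon only and no hydrogen-bond acceptor, and the read-out is still near zero, as it is with pyridin-4-yl, pyridin-3-yl and 4-nitrophenyl. Nothing available here explains why all four compounds sit so close to zero.

Every group shown on this nitrogen is joined to it through an aromatic ring, so the compounds leave open whether a benzyl group, a cyclohexyl ring or a simple ethyl chain there would give any measurable inhibition. They also leave open whether a change elsewhere on the shared core, such as a different group in place of the 4-chlorophenyl ring or the free amine, would move the read-out beyond the scatter.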